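Trading thiophen-2-yl for 3,4,5-trimethoxyphenyl on compound 1

The source may hold more compounds than are shown below. What is called first, only, known or untested is meant among the compounds shown, and "the series" means these compounds.

In a functional assay on HCT-116 cells (Homo sapiens) for inhibition, read by sulforhodamine B assay, with a stated time of 48 h, tested at 50 uM (a lower number here means less inhibition of growth, a higher number more inhibition of growth at the concentration tested), compound 1 (`COc1cc(/C=C/C(=O)/C=C/c2cccs2)ccc1OCc1cn(CCCCCOc2cc(=O)oc3ccccc23)nn1`) gives 31% as the lower of two numbers, and compound 2 (`COc1ccc(/C=C/C(=O)/C=C/c2ccc(OCc3cn(CCCOc4cc(=O)oc5ccccc45)nn3)c(OC)c2)cc1`) gives 54% as the higher, a gap beyond the scatter. Compound 3 (`COc1cc(/C=C/C(=O)/C=C/c2cc(OC)c(OC)c(OC)c2)ccc1OCc1cn(CCCCCOc2cc(=O)oc3ccccc23)nn1`) departs from compound 1 by one change (3,4,5-trimethoxyphenyl in place of thiophen-2-yl on a double-bonded chain carbon bound to a double-bonded chain carbon): 3,4,5-trimethoxyphenyl in place of thiophen-2-yl on a double-bonded chain carbon bound to a double-bonded chain carbon. Within the data shown here, compound 2 differs from compound 1 in more than one place, so no measured pair isolates this change and the expectation is loose. A rise somewhat beyond the scatter is expected, with an estimated step (a number 14 percentage points higher from compound 1 to compound 3 (beyond the scatter)) in this assay as its size. Compound 3 is expected to give an estimated 45% (25% to 66%).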

Compound 3, percent growth inhibition at one concentration: 53%
Estimate against measurement, compound 3: 8 percentage points below; the range from low to high includes it.
By their numbers in this assay, from the lowest: compound 1; then compounds 3 and 2 (each within the scatter of the next).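

In this assay, the exchange of thiophen-2-yl for 3,4,5-trimethoxyphenyl gives a number 22 percentage points higher from compound 1 to compound 3 (beyond the scatter). Among these compounds, this is the first pair to isolate this position, and it shows that a change here alone, with the rest of compound 1 kept, moves growth inhibition beyond the scatter. Nothing at hand says what lies behind this step.

From the compounds shown here alone, whether the methoxy groups or the six-membered aromatic ring carries the step remains open. So does whether an unsubstituted phenyl or a dimethylaminophenyl group would serve at this position.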